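Hydroxy to 2-aminophenyl swap on the amide nitrogen

The source may report more compounds than this note shows. Statements on the series, on what has been measured and on what is new or still open speak of the compounds shown alone.

Of the compounds shown here, three have been measured in an assay on isolated protein for inhibition of protein deacetylase HDAC6 (Homo sapiens), read by fluorescence, with a stated time of 15 min; a lower number here means a stronger inhibitor, a higher number a weaker inhibitor. Compound 3 `O=C(NO)c1ccc(Cc2nnc(Cc3cccc4ccccc34)o2)cc1` gives 1200 nM. Compound 1 `Nc1ccccc1NC(=O)c1ccc(Cc2nnc(Cc3cccc4ccccc34)o2)cc1` is its direct counterpart in which the amide nitrogen carries a 2-aminophenyl group instead of hydroxy; in this assay compound 1 gives 8900 nM. That change, (2-aminophenyl in place of hydroxy on an amide-type nitrogen), produces a 7.4-fold higher number from compound 3 to compound 1 (0.87 log units; beyond the scatter), a modest loss that is beyond the scatter.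

Among the compounds with values here, compound 2 `O=C(/C=C/c1ccc(-c2nnc(Cc3cccc4ccccc34)o2)cc1)NO` has the lowest number so far, giving 60 nM in this assay; the difference between its core and the core of compound 3 is not broken down here, and it stands well apart from both compound 3 and compound 1.

Compound 4 `Nc1ccccc1NC(=O)/C=C/c1ccc(-c2nnc(Cc3cccc4ccccc34)o2)cc1` has not yet been measured in this assay. It differs from compound 2 by 2-aminophenyl in place of hydroxy on an amide-type nitrogen, the same change already seen from compound 3 to compound 1, at the same place. Within the data shown here, the only anchor is the step measured on the other core: the expectation is that compound 4 sits weaker than compound 2 by roughly the amount seen from compound 3 to compound 1, with some room for a larger loss, because only one earlier step, a 7.4-fold higher number from compound 3 to compound 1 (0.87 log units; beyond the scatter), is available and the cores are not the same. For compound 4 the expected step is a 10-fold higher number from compound 2 to compound 4 (1.00 log units; beyond the scatter). Compound 4 is therefore estimated at 600 nM in this assay, within 150 nM to 5000 nM.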

Compound 4, half-maximal inhibitory concentration: > 20000 nM
Compound 4 was reported as a limit; the forecaster's own chance of this, stated with the estimate: 10%; at least 33-fold (1.52 log units) between middle value and limit.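

The change from hydroxy to 2-aminophenyl on an amide-type nitrogen gives an at least 330-fold higher number from compound 2 to compound 4 (2.52 log units; beyond the scatter), and its size in this assay does not carry over from the core of compound 3 to the core of compound 2: the same change on two cores in this assay, a 7.4-fold higher number (0.87 log units; beyond the scatter) from compound 3 to compound 1 and an at least 330-fold higher number (2.52 log units; beyond the scatter) from compound 2 to compound 4, at least 44-fold (1.65 log units) apart, beyond the scatter of two such steps

Compound 4 gives > 20000 nM, which is a limit of the assay and not a number: the limit of > 20000 nM in this assay, at which 1 of the 4 values shown sits.

The direction of the change is the same in both pairs, with the higher number on the 2-aminophenyl side each time, but two pairs give no rule for the size of the step on any other core, and they do not show which part of the core goes with the larger step.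

The difference between the two cores is not broken down by the compounds shown, so it remains open which of its parts goes with the gap between the two steps. Also open, from the compounds shown here alone, is how the series responds when the hydroxycarbamoyl group gives way to a carboxylic acid, or when the amide-type nitrogen carries a methyl group instead of hydroxy or 2-aminophenyl, on either core.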